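A few compounds are considered here, and "the series" means these few. Any claim that something is new, unique, unknown or untested is made for them only; others in the source may bear on it.

Of the compounds shown here, two have been measured in an assay on isolated protein with metabotropic glutamate receptor 2 (Homo sapiens) as the target; on this read-out lower numbers stand for an effect already at smaller amounts and higher numbers for an effect only at larger amounts of compound. Compound 1 `CCS(=O)(=O)N(Cc1cccnc1)c1ccc(C(=O)c2ccccc2)cc1` gives 4200 nM. Compound 2 `C=C(c1ccccc1)c1ccc(N(Cc2cccnc2)S(=O)(=O)CC)cc1` gives 780 nM. Among the compounds with values here, the single change between them, a 1-phenylethenyl in place of benzoyl on an aromatic carbon, brought a 5.4-fold lower number from compound 1 to compound 2 (0.73 log units; beyond the scatter). Compound 2 therefore stands at the lower of the two numbers, with compound 1 sitting a clear step above it.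

Compound 3 `CCS(=O)(=O)N(Cc1cccnc1)c1ccc(C(C)c2ccccc2)cc1` is not yet measured. It differs from compound 2 in one place: 1-phenylethyl in place of 1-phenylethenyl on an aromatic carbon. Within the data shown here, only one measured step exists, and it bears on this change loosely at best: that step swapped a carbonyl for a double bond to carbon, whereas the change to compound 3 keeps the eight-carbon group and removes the double bond. Among the measured compounds shown here, no measured pair shows what losing that double bond alone does, so no direction can be read from the data.

The expectation is that compound 3 stays close to compound 2, with a step of a 1.3-fold higher number from compound 2 to compound 3 (0.11 log units; within the scatter) that is not expected to exceed the scatter. Compound 3 is estimated at 1000 nM, within a range from 350 nM to 3000 nM.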

Compound 3, half-maximal effective concentration: 1400 nM
Estimate against measurement, compound 3: 1.4-fold (0.15 log units) below; the measured number falls inside the stated range.
By their numbers in this assay, from the lowest: compounds 2 and 3 (each within the scatter of the next); then compound 1.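

In this assay, putting 1-phenylethyl in place of 1-phenylethenyl on the aromatic carbon para to a large group gives a 1.8-fold higher number from compound 2 to compound 3 (0.25 log units; within the scatter), so at this position the double bond outside the aromatic ring can go without a difference that stands out from the scatter. Putting the same 1-phenylethyl in place of benzoyl gives a 3.0-fold lower number from compound 1 to compound 3 (0.48 log units; beyond the scatter), which means that a second group without the carbonyl now also lies clearly under benzoyl, and among these three compounds benzoyl carries the highest number, with no compound going against that. Nothing measured here explains why compound 1 stands apart from the other two.

Still open, from the compounds shown here alone, is whether a benzyl or a phenoxy group at this place would fall with compounds 2 and 3 or with compound 1, and whether a 1-hydroxy-1-phenylethyl group, which puts an oxygen back on the same carbon, would behave like benzoyl. The compounds shown also leave open how far a fluorine or a methoxy on the outer phenyl ring would move the number, and whether the pattern holds when the rest of the shared core differs.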